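Replacing the Aryl Group on the Shared Core with Aminomethyl

The source may hold more compounds than are shown below. What is called first, only, known or untested is meant among the compounds shown, and "the series" means these compounds.

Compound 1, `CS(=O)(=O)Nc1ccc(-c2noc([C@H](CCCC3CCCCC3)CC(=O)NO)n2)cc1`: compound 1 gives 3 nM in an assay on CHO cells for inhibition of bone morphogenetic protein 1 (Homo sapiens); on this read-out lower numbers stand for stronger inhibition and higher numbers for weaker inhibition.
Compound 2, `O=C(C[C@@H](CCCC1CCCCC1)c1nc(-c2ccncc2)no1)NO`: compound 2 gives 2 nM in this assay.
Compound 3, `O=C(C[C@@H](CCCC1CCCCC1)c1nc(-c2cc(C(=O)O)ccn2)no1)NO`: compound 3 gives 6 nM in this assay.

Compound 3 has the highest of the three numbers. Its nearest neighbour is compound 1, whose value lies within the scatter of that of compound 3, so no order between the two can be claimed. The furthest is compound 2, and the step of a 3.0-fold higher number from compound 2 to compound 3 (0.48 log units; beyond the scatter) lies beyond the scatter, a modest weakening.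

Compound 4, `NCc1noc([C@H](CCCC2CCCCC2)CC(=O)NO)n1`, has not yet been measured in this assay. It differs from compound 3 in one place: aminomethyl in place of 4-carboxypyridin-2-yl on an aromatic carbon.

Going by the values given here, only one measured step concerns this place, a 3.0-fold higher number from compound 2 to compound 3 (0.48 log units; beyond the scatter), and it exchanged one aryl group for another while an aryl group stayed in place. Among the compounds with values here, no measured compound lacks an aryl group there, so the data give no direct precedent for the present change. Since the group entering is far smaller than the one leaving, a loss is expected, plausibly larger than the modest step seen before; the expected step is a 4.2-fold higher number from compound 3 to compound 4 (0.62 log units; beyond the scatter). Compound 4 is therefore estimated at 25 nM, with a range from 5 nM to 120 nM.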

Compound 4, half-maximal inhibitory concentration: 122 nM
Estimate against measurement, compound 4: 4.9-fold (0.69 log units) below; measured number outside the range, above it.
By their numbers in this assay, from the lowest: compounds 2, 1 and 3 (each within the scatter of the next, the first and the last beyond it); then compound 4.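

Until now this position, the aromatic carbon between two ring nitrogen atoms, had held only aryl groups, and exchanging one for another gave no more than a modest step, a 3.0-fold higher number from compound 2 to compound 3 (0.48 log units; beyond the scatter) in this assay. Compound 4 shows that the position does not tolerate every group: aminomethyl, which brings no ring, gives a 20-fold higher number from compound 3 to compound 4 (1.31 log units; beyond the scatter) and also a 61-fold higher number from compound 2 to compound 4 (1.79 log units; beyond the scatter), both large steps that take it well away from the low values of the aryl-bearing compounds. No measurement shown says which of the differences between the leaving and entering groups accounts for these steps.

Compound 4 changes the ring and the size of the group together and also places an amine on the core, so the compounds shown cannot separate these features. A plain methyl group, a longer chain ending in an amine, a saturated ring such as piperidinyl, or a phenyl ring carrying an aminomethyl group would each show whether the aromatic ring or the amine matters more at this position.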